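One Methyl Swapped for Hydrogen at the Assay Limit

This account rests on a few compounds, and the source may have more. Where it says the series, first, only, none or still open, it means among the compounds named here.

In an ADME assay on L1210/0 cells (Mus musculus) for cytotoxicity, with a stated time of 48 h (on this read-out higher numbers stand for weaker inhibition and lower numbers for stronger inhibition), compound 1 (`O=C(CI)NCc1cn([C@H]2C[C@H](O)[C@@H](CO)O2)c(=O)[nH]c1=O`) gives 107000 nM as a measured number.

Compound 2 (`COc1c(C)c(C)c(OC)c(-c2cn([C@H]3C[C@H](O)[C@@H](CO)O3)c(=O)[nH]c2=O)c1C`) gives > 200000 nM as its reading, and this is a limit of the assay rather than a number. Compound 2 therefore has no exact place on the scale, and the data so far hold the limit of > 200000 nM in this assay, at which 1 of the 2 values shown sits, as their only such case.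

Compound 3 (`COc1cc(-c2cn([C@H]3C[C@H](O)[C@@H](CO)O3)c(=O)[nH]c2=O)c(OC)c(C)c1C`) differs from compound 2 in one place on a six-membered aromatic ring of carbon only, where hydrogen stands in place of methyl on an aromatic carbon (hydrogen in place of methyl on an aromatic carbon). Among the measured compounds shown here, no measured pair shows what this swap does on its own. For the measured compounds named here, the only guide is compound 2 with its > 200000 nM reading, so no change beyond the usual scatter of this assay is expected, in either direction. In numbers, the estimated move is a number no higher from compound 2 to compound 3 (the limit leaves the size open) on this scale. Compound 3 may well stop at a limit too. For compound 3 the estimated value is 200000 nM with an expected range from 90000 nM to 400000 nM as the likely span.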

Compound 3, half-maximal inhibitory concentration: > 200000 nM
Compound 3: no number, only a limit; the forecaster's own chance of this, stated with the estimate: 60%; the middle value sits exactly at the limit.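

Among the compounds shown here, compound 2 and compound 3 both stop at a limit of the assay and not at a number, and no step between them can be read. On these data alone, whether hydrogen in place of methyl on an aromatic carbon changes the reading at all, and by how much, stays open, as does the exact place of either compound on the scale.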